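N-substitution of the pyrrolidine amine: cyclohexylmethyl analogue

The compounds below may be only part of what the source reports. "The series", "measured", "known", "first", "only" and "open" are said of these compounds alone.

Compound 1 `CN(C(=O)N1CC[C@H](n2cnc3cc(-c4ccc(Cl)cc4)sc3c2=O)C1)[C@H]1CCNC1` carries a free amine nitrogen in its five-membered ring. In a functional assay for antagonist activity at melanin-concentrating hormone receptor 1 (Homo sapiens), read by GTPgammaS binding (on this read-out higher numbers stand for weaker inhibition and lower numbers for stronger inhibition), compound 1 gives 29 nM. Among the measured compounds shown here, of the two numbers measured so far this is the higher one; the only comparison is compound 2 `CN(C(=O)N1CC[C@H](n2cnc3cc(-c4ccc(Cl)cc4)sc3c2=O)C1)[C@H]1CCN(C2CCC(C)(C)CC2)C1`, which in this assay gives 10 nM. For the measured compounds named here, the single step available, a 2.9-fold lower number from compound 1 to compound 2 (0.46 log units; beyond the scatter), shows that placing 4,4-dimethylcyclohexyl on the ring amine nitrogen lowers the number by a modest amount that is beyond the scatter.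

Compound 3 `CN(C(=O)N1CC[C@H](n2cnc3cc(-c4ccc(Cl)cc4)sc3c2=O)C1)[C@H]1CCN(CC2CCCCC2)C1` is not yet measured. It differs from compound 1 as follows: cyclohexylmethyl in place of hydrogen on an amine nitrogen in a ring. The group entering is again a six-membered saturated carbon ring on the same amine nitrogen, here attached through one additional carbon, so the step from compound 1 to compound 2 is the one that bears on it. On that basis a modest lowering of the number is expected, a 2.4-fold lower number from compound 1 to compound 3 (0.38 log units; beyond the scatter), with some chance that the step stays within the scatter. Compound 3 is therefore estimated at 12 nM in this assay, with a range from 4 nM to 35 nM.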

Compound 3, half-maximal inhibitory concentration: 53 nM
Compound 3: the middle estimate sits 4.4-fold (0.65 log units) below what was measured; the whole stated range lies below it.
By their numbers in this assay, from the lowest: compound 2; then compounds 1 and 3 (each within the scatter of the next).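

Placing a saturated carbon ring on this amine nitrogen does not by itself shift the result in this assay: cyclohexylmethyl in place of hydrogen gives a change that stays within the scatter (a 1.8-fold higher number from compound 1 to compound 3 (0.26 log units; within the scatter)). The outcome at this position depends on the identity of the group, since exchanging 4,4-dimethylcyclohexyl for cyclohexylmethyl gives a step beyond the scatter (a 5.3-fold higher number from compound 2 to compound 3 (0.72 log units; beyond the scatter)), and the lowering seen with 4,4-dimethylcyclohexyl does not carry over to its cyclohexylmethyl counterpart. Nothing available accounts for this difference between the two groups.

Cyclohexylmethyl and 4,4-dimethylcyclohexyl differ both in the carbon of attachment and in the dimethyl substitution, so the compounds shown do not separate these two changes; unsubstituted cyclohexyl and 4,4-dimethylcyclohexylmethyl on the same nitrogen would bear directly on that question. Also open, on these data alone, is how this position responds to a longer chain between the nitrogen and the ring, or to a ring containing oxygen, such as tetrahydropyranyl.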